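The compounds below may be only part of what the source reports. "The series", "measured", "known", "first", "only" and "open" are said of these compounds alone.

Working notes on the diaryl-pentyl urea series, assessed in a functional assay on MDA-MB-231 cells (Homo sapiens) for cytotoxicity, read by MTT assay, with a stated time of 48 h; on this read-out higher numbers stand for weaker inhibition and lower numbers for stronger inhibition.

The parent is compound 1 `CC(=O)Nc1ccc(NC(=O)NCCCCC(c2ccc(F)cc2)c2ccc(F)cc2)cc1`. In this assay compound 1 gives > 20000 nM, which is a limit of the assay and not a number, so compound 1 stands only at the weak edge of what this assay can report (the limit of > 20000 nM in this assay, at which 1 of the 3 values shown sits). Two measured analogues replace the 4-acetamidophenyl on the urea nitrogen. Compound 2 `O=C(NCCCCC(c1ccc(F)cc1)c1ccc(F)cc1)Nc1cccc([N+](=O)[O-])c1` gives 3790 nM in this assay. Compound 3 `O=C(NCCCCC(c1ccc(F)cc1)c1ccc(F)cc1)Nc1ccc([N+](=O)[O-])c(Cl)c1` gives 3470 nM in this assay. The step of an at least 5.2-fold lower number from compound 1 to compound 2 (0.72 log units; beyond the scatter) and the step of an at least 5.7-fold lower number from compound 1 to compound 3 (0.76 log units; beyond the scatter) both move away from the limit in the same direction; the step of a 1.1-fold lower number from compound 2 to compound 3 (0.04 log units; within the scatter) shows that the two substituted aryl groups are not separated on this read-out.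

Compound 4 `O=C(NCCCCC(c1ccc(F)cc1)c1ccc(F)cc1)Nc1ccc(Cl)cc1C(F)(F)F` is not yet measured. It differs from compound 1 by 4-chloro-2-(trifluoromethyl)phenyl in place of 4-acetamidophenyl on an amide-type nitrogen. Both measured steps from compound 1 bear on this change, each being a replacement of the 4-acetamidophenyl by a halogen- or nitro-bearing aryl group, and each gave at least a modest move to lower numbers. A step of similar size, in the same direction, is therefore expected for compound 4, expressed as an at least 5.0-fold lower number from compound 1 to compound 4 (0.69 log units; beyond the scatter). Compound 4 is estimated at 4000 nM in this assay, with a range from 1500 nM to 12000 nM.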

Compound 4, half-maximal inhibitory concentration: > 20000 nM
Compound 4: a limit, no number; the forecaster's own chance of this, stated with the estimate: 15%; middle value at least 5.0-fold (0.69 log units) away from the limit.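

In this assay compound 4 gives > 20000 nM and this is a limit and not a number, so compound 4 stands with compound 1 at the weak edge of what can be reported: the limit of > 20000 nM in this assay, at which 2 of the 4 values shown sit.

The earlier compounds shown here showed only moves to lower numbers on leaving the 4-acetamidophenyl, whereas this result shows that such a move does not follow from every replacement on the amide-type nitrogen. The 4-chloro-2-(trifluoromethyl)phenyl separates clearly from both nitro-bearing aryl groups, with an at least 5.2-fold higher number from compound 2 to compound 4 (0.72 log units; beyond the scatter) and an at least 5.7-fold higher number from compound 3 to compound 4 (0.76 log units; beyond the scatter) on the same amide-type nitrogen. Among the four compounds shown, only compound 2 and compound 3 carry a nitro group and only they give numbers, while the step between compound 1 and compound 4 cannot be read, both ends being limits.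

The compounds shown leave open whether the nitro group itself sets compound 2 and compound 3 apart, as the aryl groups of these compounds differ from that of compound 4 in more than one feature. A nitrile, a carboxylic acid or an amine in place of the nitro group would bear directly on this question.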